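Swapping the cyclopentylcarbonyl amide for an isopropyl amine

A few compounds are considered here, and "the series" means these few. Any claim that something is new, unique, unknown or untested is made for them only; others in the source may bear on it.

Compound 1 `Nc1ncc(-c2cccc(Cl)c2)c(-c2ccccc2)n1`: > 80%
Compound 2 `O=C(Nc1ncc(-c2cccc(Cl)c2)c(-c2ccccc2)n1)C1CCCC1`: 47%

In an assay on CHO cells for displacement of a labelled ligand from adenosine receptor A1 (Homo sapiens), read by scintillation counting, with a stated time of 1 h, tested at 1 uM (on this read-out higher numbers stand for more inhibition at the one concentration tested (going by the name of the read-out) and lower numbers for less inhibition), compound 1 gives > 80%, which is a limit of the assay rather than a number. Compound 2 gives 47% in this assay, the only plain number shown. Compound 3 `CC(C)Nc1ncc(-c2cccc(Cl)c2)c(-c2ccccc2)n1` differs from compound 2 by isopropyl in place of cyclopentylcarbonyl on a nitrogen on an aromatic ring. For the measured compounds named here, one measured step bears on this change, at the same nitrogen: a number at least 33 percentage points lower from compound 1 to compound 2 (beyond the scatter). Removing the cyclopentylcarbonyl again, now for isopropyl rather than hydrogen, is expected to recover part of that loss. Compound 3 is therefore estimated at 65% (range 40% to 88%), an expected step of a number 18 percentage points higher from compound 2 to compound 3 (beyond the scatter).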

Compound 3, a percentage reported as inhibition, at one concentration (the size of the read-out at that concentration, not a potency): 71%
For compound 3 the middle estimate is 6 percentage points below the measured one; low and high end bracket the measured number.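

Exchanging cyclopentylcarbonyl for isopropyl on this nitrogen gives a number 24 percentage points higher from compound 2 to compound 3 (beyond the scatter), so the nitrogen can carry a substituent without the full loss seen with the amide. Against the free amine, isopropyl gives a number at least 9 percentage points lower from compound 1 to compound 3 (that floor lies within the scatter), so no real loss from hydrogen can be claimed. Compound 1 gives a limit and not a number, and the size of that last step stays uncertain because of it: the limit of > 80% in this assay, at which 1 of the 3 values shown sits.

On these data alone, whether the carbonyl or the cyclopentyl ring drives the difference stays open. A cyclopentyl amine or an isobutyryl amide on this nitrogen would separate the two.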